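The source may report more compounds than this note shows. Statements on the series, on what has been measured and on what is new or still open speak of the compounds shown alone.

Measured compounds:
- compound 1, `CCCCCC(CCO)n1cnc2c(Cl)ncnc21`: > 50000 nM
- compound 2, `CCCCCC(CCO)n1c(Br)nc2c(Cl)ncnc21`: 23800 nM
- compound 3, `CCCCCCCC(CCO)n1cnc2c(Cl)ncnc21`: 3630 nM

In a functional assay on SW480 cells (Homo sapiens) for antiproliferative activity, read by MTT assay, with a stated time of 48 h (on this read-out lower numbers stand for stronger inhibition and higher numbers for weaker inhibition), compound 1 gives only a limit, > 50000 nM, and no number; this is the limit of > 50000 nM in this assay, at which 1 of the 3 values shown sits. Compound 2 gives 23800 nM in this assay. Compound 3 gives 3630 nM in this assay, the lowest number among the measured pair of numbers.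

Two changes have been made from compound 1. The first, (bromo in place of hydrogen on an aromatic carbon), gives an at least 2.1-fold lower number from compound 1 to compound 2 (0.32 log units; beyond the scatter); as it starts from a limit, its true size is not known. The second, (ethyl in place of hydrogen on a saturated chain carbon, six bonds along the chain from an aromatic nitrogen), gives an at least 13-fold lower number from compound 1 to compound 3 (1.13 log units; beyond the scatter).

Compound 4, `CCCCCCCC(CCO)n1c(Br)nc2c(Cl)ncnc21`, has not been measured in this assay. It differs from compound 3 by bromo in place of hydrogen on an aromatic carbon. For the measured compounds named here, this is the same kind of change as the one from compound 1 to compound 2, made on the core of compound 3 rather than on the core of compound 1; the two places differ only in that the neighbouring ring atom bears a group of 9 heavy atoms in compound 1 and a large group in compound 3. The cores themselves differ by ethyl in place of hydrogen on a saturated chain carbon, six bonds along the chain from an aromatic nitrogen.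

The step from compound 3 to compound 4 is expected to be a 3.0-fold lower number from compound 3 to compound 4 (0.48 log units; beyond the scatter), a modest lowering comparable to or somewhat larger than an at least 2.1-fold lower number from compound 1 to compound 2 (0.32 log units; beyond the scatter), which rests on that single measured instance of the change and on its start from a limit. For compound 4 the estimated value in this assay is 1200 nM, with an expected range from 400 nM to 4000 nM.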

Compound 4, half-maximal inhibitory concentration: 14400 nM
Compound 4: middle estimate off by 12-fold (1.08 log units), on the low side, outside the stated range (above it).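

In this assay, bromo in place of hydrogen on an aromatic carbon does not carry over between these two cores: on the core of compound 3 it gives a 4.0-fold higher number from compound 3 to compound 4 (0.60 log units; beyond the scatter), the opposite direction to the step on the core of compound 1, and the two steps differ: the same change on two cores in this assay, an at least 2.1-fold lower number (0.32 log units; beyond the scatter) from compound 1 to compound 2 and a 4.0-fold higher number (0.60 log units; beyond the scatter) from compound 3 to compound 4, at least 8.3-fold (0.92 log units) apart, beyond the scatter of two such steps

The ethyl change does not carry over either: on the bromo core it gives a 1.7-fold lower number from compound 2 to compound 4 (0.22 log units; within the scatter), so the clear lowering seen without bromo is absent here, and the two steps differ: the same change on two cores in this assay, an at least 13-fold lower number (1.13 log units; beyond the scatter) from compound 1 to compound 3 and a 1.7-fold lower number (0.22 log units; within the scatter) from compound 2 to compound 4, at least 8.3-fold (0.92 log units) apart, beyond the scatter of two such steps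

Two cores set no general rule and do not show why the steps differ, and the true size of each gap stays unknown, as both comparisons start from compound 1, which gives only a limit: the limit of > 50000 nM in this assay, at which 1 of the 4 values shown sits.

Open, as far as these compounds go, is whether a chloro or an amine in the place of bromo would also change direction between the two cores. Also open, from the compounds shown here alone, is whether a longer chain would keep the lower number of compound 3, and how bromo would behave on such a chain.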